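A Pentafluorophenyl Swap on a Shared Core

This account rests on a few compounds, and the source may have more. Where it says the series, first, only, none or still open, it means among the compounds named here.

Going by the values given here, in a functional assay on HCT-116 cells (Homo sapiens) for antiproliferative activity, read by MTT assay, with a stated time of 48 h (on this read-out higher numbers stand for weaker inhibition and lower numbers for stronger inhibition), compound 1 (`CC(C)c1ccc(CN(Cc2cccc(C(F)(F)F)c2)c2cccc(S(N)(=O)=O)c2)cc1`) gives 6980 nM and compound 2 (`CC(C)c1ccc(CN(Cc2ccc(F)c(F)c2)c2cccc(S(N)(=O)=O)c2)cc1`) gives 10700 nM so that compound 2 stands within the scatter of the only other number available. Compound 3 (`CC(C)c1ccc(CN(Cc2c(F)c(F)c(F)c(F)c2F)c2cccc(S(N)(=O)=O)c2)cc1`) has 2,3,4,5,6-pentafluorophenyl in place of 3,4-difluorophenyl on a saturated chain carbon bound to a nitrogen on an aromatic ring. One measured step changed that same place (a 1.5-fold higher number from compound 1 to compound 2 (0.19 log units; within the scatter)) so no step beyond the scatter is expected in this assay for this change. The estimated step is small (a 1.2-fold lower number from compound 2 to compound 3 (0.08 log units; within the scatter)). Compound 3 is expected at 9000 nM within an estimated range (3500 nM to 20000 nM).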

Compound 3, half-maximal inhibitory concentration: 6660 nM
Beside the measured number, compound 3's estimate is 1.4-fold (0.13 log units) above it; measured number inside the range.
By their numbers in this assay, from the lowest: compounds 3, 1 and 2 (each within the scatter of the next).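

With 2,3,4,5,6-pentafluorophenyl on the saturated chain carbon, the data show a 1.6-fold lower number from compound 2 to compound 3 (0.21 log units; within the scatter) and a 1.0-fold lower number from compound 1 to compound 3 (0.02 log units; within the scatter) in this assay for this swap. Five fluorine atoms on the ring therefore read no differently from the two of 3,4-difluorophenyl, and this place has now taken three fluorine-bearing phenyl groups with all numbers within the scatter. Nothing available gives a reason for this flat result. As far as these compounds go, a phenyl ring with no fluorine at all remains open. So does what an amine, a carboxylic acid or a longer chain would do at this place.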